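A few compounds are considered here, and "the series" means these few. Any claim that something is new, unique, unknown or untested is made for them only; others in the source may bear on it.

The series rests on the core of compound 1 `C[C@@H](/N=C(\S)Nc1ccccn1)c1cccc2ccccc12`. In a functional assay on RBL-2H3 cells (Rattus norvegicus) for inhibition (a lower number here means a stronger inhibitor, a higher number a weaker inhibitor), compound 1 gives > 100000 nM, which is a limit of the assay and not a number. Compound 2 `C[C@@H](/N=C(\S)Nc1nccs1)c1cccc2ccccc12` carries a 1,3-thiazol-2-yl in place of pyridin-2-yl on the amine nitrogen. In this assay compound 2 gives > 100000 nM, again a limit of the assay rather than a number. The step that the two limits leave unreadable from compound 1 to compound 2 cannot be read, because the limit of > 100000 nM in this assay, at which 2 of the 2 values shown sit, holds both of the values shown. Compound 2 therefore stands at that limit, and nothing measured ranks it against compound 1.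

Compound 3 `Cc1csc(N/C(S)=N/[C@H](C)c2cccc3ccccc23)n1` differs from compound 2 by methyl in place of hydrogen on an aromatic carbon. For the measured compounds named here, no measured step speaks to this change; the only step known, a step that the two limits leave unreadable from compound 1 to compound 2, is itself unreadable, so there is no ground for expecting movement in either direction. Compound 3 is expected to stay in the same region, with an estimate of 150000 nM spanning 30000 nM to 600000 nM. The step that the limit leaves unreadable from compound 2 to compound 3 is thus expected to be none beyond the scatter, and most likely only a further limit will be reported.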

Compound 3, half-maximal inhibitory concentration: 25900 nM
Beside the measured number, compound 3's estimate is 5.8-fold (0.76 log units) above it, and the stated range ends above it.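

For the compounds shown here, compound 3 is the first compound to give a number rather than a limit of the assay, so a change on this ring can now be read in this assay. Methyl on the aromatic carbon of the five-membered ring, next to the ring nitrogen and two ring bonds from the ring atom that bears the large group, gives an at least 3.8-fold lower number from compound 2 to compound 3 (0.58 log units; beyond the scatter), and the exchange of pyridin-2-yl for 4-methyl-1,3-thiazol-2-yl gives an at least 3.8-fold lower number from compound 1 to compound 3 (0.58 log units; beyond the scatter). Both sizes are only lower bounds, and the true steps may be larger, because each of the two starting compounds stands at a limit and not at a number: the limit of > 100000 nM in this assay, at which 2 of the 3 values shown sit.

From the compounds shown here alone, it remains open whether an ethyl group, a longer chain, an amine or a carboxylic acid on the same ring carbon would move the number further than methyl does, or would lose what methyl gains. Going by these compounds, it is also open whether methyl on the pyridin-2-yl ring of compound 1 would bring that compound to a measurable number as well.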